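Nitroimidazole swap on the propyl ether of compound 1

A few compounds are considered here, and "the series" means these few. Any claim that something is new, unique, unknown or untested is made for them only; others in the source may bear on it.

Three analogues of one quinazoline-free description: the shared core carries an anilino group and a methoxy-bearing ether chain that ends in a nitroimidazole. Compound 1 `COc1cc2ncnc(Nc3cccc(Br)c3)c2cc1OCCCn1ccnc1[N+](=O)[O-]` gives 4010 nM in a functional assay on HT-29 cells (Homo sapiens) for cytotoxicity, read by sulforhodamine B assay, with a stated time of 72 h; on this read-out higher numbers stand for weaker inhibition and lower numbers for stronger inhibition. Compound 2 `C#Cc1cccc(Nc2ncnc3cc(OC)c(OCCCn4ccnc4[N+](=O)[O-])cc23)c1` gives 5530 nM, and compound 3 `C#Cc1cccc(Nc2ncnc3cc(OC)c(OCCCCCCn4ccnc4[N+](=O)[O-])cc23)c1` gives 3460 nM. Compound 1 stands second highest of the three numbers; its nearest neighbour is compound 3 and its furthest is compound 2, and the steps of a 1.4-fold higher number from compound 1 to compound 2 (0.14 log units; within the scatter) and a 1.6-fold lower number from compound 2 to compound 3 (0.20 log units; within the scatter) both lie within the scatter.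

Compound 4 `COc1cc2ncnc(Nc3cccc(Br)c3)c2cc1OCCCn1c([N+](=O)[O-])cnc1C` differs from compound 1 by 2-methyl-5-nitro-1H-imidazol-1-yl in place of 2-nitro-1H-imidazol-1-yl on a saturated chain carbon, three bonds along the chain from an oxygen on an aromatic ring. Neither measured step touches the nitroimidazole itself: one exchanges the aryl substituent, the other lengthens the chain. For the measured compounds named here, there is thus no measured precedent for this change, and the series so far has moved only within the scatter. The expected step is a 1.0-fold lower number from compound 1 to compound 4 (0.00 log units; within the scatter), no change beyond the scatter. Compound 4 is therefore estimated at 4000 nM, between 1800 nM and 9000 nM.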

Compound 4, half-maximal inhibitory concentration: 5410 nM
Beside the measured number, compound 4's estimate is 1.4-fold (0.13 log units) below it; measured number inside the range.
By their numbers in this assay, from the lowest: compounds 3, 1, 4 and 2 (each within the scatter of the next).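

For the compounds shown here, this is the first measured change to the nitroimidazole itself. In this assay, 2-methyl-5-nitro-1H-imidazol-1-yl in place of 2-nitro-1H-imidazol-1-yl on a saturated chain carbon, three bonds along the chain from an oxygen on an aromatic ring, gives a 1.3-fold higher number from compound 1 to compound 4 (0.13 log units; within the scatter), so this read-out does not separate the two groups at this place. No available evidence bears on this result.

The step combines an added methyl with a move from 2-nitro to 5-nitro, and the compounds shown cannot separate these two differences. On these data alone, it also remains open whether a group of another kind at this place, such as an unsubstituted imidazole, an amine or a carboxylic acid, would move the number beyond the scatter.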